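Trifluoromethoxy in place of trifluoromethyl on compound 1

This account rests on a few compounds, and the source may have more. Where it says the series, first, only, none or still open, it means among the compounds named here.

Measured so far in an ADME assay on the whole organism (plasma, strain Balb/c) for pharmacokinetics, with Mus musculus as the target, read by LC-MS, at a dose of 3 mg/kg by the intravenous route; on this read-out higher numbers stand for higher exposure at the dose given and lower numbers for lower exposure:
- compound 1 `CC(Oc1ccc(F)c(C(N)=O)c1F)c1nc(-c2ccc(C(F)(F)F)cc2)c(Br)o1` gives 2200 ng.h/mL
- compound 2 `CCCc1oc(COc2ccc(F)c(C(N)=O)c2F)nc1-c1ccc(Cl)cc1` gives 400 ng.h/mL

Compound 1 stands highest of these two, and its gap to compound 2 lies beyond the scatter. Compound 3 `CC(Oc1ccc(F)c(C(N)=O)c1F)c1nc(-c2ccc(OC(F)(F)F)cc2)c(Br)o1` keeps the core of compound 1 but has trifluoromethoxy in place of trifluoromethyl on an aromatic carbon. Going by the values given here, no measured pair differs by this change alone, so its size remains unknown. In this assay no step beyond the scatter is expected. The estimated change is a 1.4-fold lower number from compound 1 to compound 3 (0.14 log units; within the scatter). Compound 3 is expected at 1600 ng.h/mL within a range from 700 ng.h/mL to 3500 ng.h/mL.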

Compound 3, area under the concentration-time curve: 1400 ng.h/mL
Compound 3: the middle estimate sits 1.1-fold (0.06 log units) above what was measured; the measured number falls inside the stated range.
By their numbers in this assay, from the lowest: compound 2; then compounds 3 and 1 (each within the scatter of the next).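

In this assay, trifluoromethoxy in place of trifluoromethyl on an aromatic carbon, para to a large group, gives the first step read at this position (a 1.6-fold lower number from compound 1 to compound 3 (0.20 log units; within the scatter)). Compound 1 and compound 3 therefore lie within the scatter of each other, so this one pair shows no measurable effect of the change on exposure. Nothing measured here offers an explanation for this result. The compounds shown leave open how a nitrile or a methoxy group would read on this aromatic carbon. They also leave open whether the same change would read alike with an amine in place of the bromine.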